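Sugar configuration reversed on a cytotoxic diterpene glycoside

A few compounds are considered here, and "the series" means these few. Any claim that something is new, unique, unknown or untested is made for them only; others in the source may bear on it.

Compound 1 `C=C[C@@](C)(CC[C@H]1C(C)=CC[C@H]2C(C)(C)CCC[C@]12C)O[C@@H]1O[C@@H](C)[C@@H](O)[C@H](O)[C@H]1O`: 8.9 ug/mL
Compound 2 `C=C[C@@](C)(CC[C@@H]1[C@@]2(C)CCCC(C)(C)[C@@H]2CC[C@@]1(C)O)O[C@H]1O[C@H](C)[C@H](O)[C@@H](O)[C@@H]1O`: > 5 ug/mL

In a functional assay on XF498 cells (Homo sapiens) for cytotoxicity, read by sulforhodamine B assay (on this read-out lower numbers stand for an effect already at smaller amounts and higher numbers for an effect only at larger amounts of compound), compound 1 gives 8.9 ug/mL. For compound 2 the assay reports no number but only a limit, > 5 ug/mL (the limit of > 5 ug/mL in this assay, at which 1 of the 2 values shown sits). Compound 3 `C=C[C@@](C)(CC[C@@H]1[C@@]2(C)CCCC(C)(C)[C@@H]2CC[C@@]1(C)O)O[C@@H]1O[C@H](C)[C@H](O)[C@H](O)[C@H]1O` has the same atoms and bonds as compound 2 and differs only in configuration: the two compounds have the same atoms and bonds and differ only in configuration as drawn: 3 of 10 stereo elements differ; a stereocentre at a saturated ring carbon is drawn R in compound 2 and S in compound 3; a stereocentre at a saturated ring carbon is drawn R in compound 2 and S in compound 3; a stereocentre at a saturated ring carbon is drawn S in compound 2 and R in compound 3. Within the data shown here, no measured pair of this kind exists here, so the size of the step is open. Compound 3 is expected at 10 ug/mL, between 4 ug/mL and 30 ug/mL, which means an expected step that the limit leaves unreadable from compound 2 to compound 3 that stays close to where compound 2 sits, with a real chance that again only a limit is reported.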

Compound 3, concentration for half-maximal effect: > 5 ug/mL
Compound 3 ended at the assay's limit; the forecaster's own chance of this, stated with the estimate: 55%; the middle value lies beyond the limit too.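

In this assay, among these compounds, compound 2 and compound 3 both end at a limit rather than a number, so no step between them can be read. Going by these compounds, how far configuration alone shifts cytotoxicity in these compounds stays open.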